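A few compounds are considered here, and "the series" means these few. Any claim that something is new, unique, unknown or untested is made for them only; others in the source may bear on it.

In a functional assay on CHO cells for positive allosteric modulation of muscarinic acetylcholine receptor M5 (Homo sapiens), read by calcium flux (on this read-out higher numbers stand for larger maximal responses and lower numbers for smaller maximal responses), compound 3 `CCN(Cc1ccccc1C(F)(F)F)C(=O)C1CCN(S(=O)(=O)c2ccc3cn[nH]c3c2)CC1` gives 92%; this number lies within the scatter of compound 1 `CCN(Cc1ccccc1)C(=O)C1CCN(S(=O)(=O)c2ccc3[nH]ncc3c2)CC1` at 86% and of compound 2 `CCN(C(=O)C1CCN(S(=O)(=O)c2ccc3[nH]ncc3c2)CC1)[C@H](C)c1ccccc1` at 86%, so the three are not separated. Among the measured compounds shown here, the only step between measured compounds, no change at the digits printed from compound 1 to compound 2 (within the scatter), concerns a different part of the molecule. Compound 4 `CCN(Cc1ccccc1C(F)(F)F)C(=O)C1CCN(S(=O)(=O)c2ccc3[nH]ncc3c2)CC1` differs from compound 3 by 1H-indazol-5-yl in place of 1H-indazol-6-yl on a sulfonyl sulfur. No measured step bears on moving the attachment point of the indazole, and the three maximal responses shown are all close to each other, so the expected step is estimated as a number 4 percentage points lower from compound 3 to compound 4 (within the scatter), which means no change beyond the scatter is expected. The estimate for compound 4 in this assay is 88%, with a range from 76% to 98%.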

Compound 4, largest response reached (reported as percent of maximum), in percent of the reference or control that the assay uses: 96%
The estimate for compound 4 lay 8 percentage points below the measured number; the measured number falls inside the stated range.
By their numbers in this assay, from the lowest: compounds 1, 2, 3 and 4 (each within the scatter of the next).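

In this assay, 1H-indazol-5-yl in place of 1H-indazol-6-yl on a sulfonyl sulfur gives a number 4 percentage points higher from compound 3 to compound 4 (within the scatter), so the two attachment points are not separated on this read-out. Trifluoromethyl in place of hydrogen on an aromatic carbon gives a number 10 percentage points higher from compound 1 to compound 4 (within the scatter), and 2-(trifluoromethyl)benzyl in place of 1-phenylethyl on an amide-type nitrogen gives a number 10 percentage points higher from compound 2 to compound 4 (within the scatter), so these changes are not separated from the scatter either. On these data alone, whether an amine or a carboxylic acid in place of trifluoromethyl on that aromatic carbon would shift the maximal response stays open. No evidence on the cause of these close responses is available.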